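The source may hold more compounds than are shown below. What is called first, only, known or untested is meant among the compounds shown, and "the series" means these compounds.

The measured compounds:
- compound 1 `O=C(c1nc2ccccc2s1)N1CCN(c2ccncc2)CC1`; in an ADME assay on RAW264.7 cells (Mus musculus) for cytotoxicity, read by MTT assay, with a stated time of 72 h, tested at 50 ug/mL (a higher number here means more inhibition at the concentration tested (going by the name of the read-out), a lower number less inhibition), compound 1 gives 62%
- compound 2 `O=C(c1nc2cc(Cl)ccc2s1)N1CCN(c2cnccn2)CC1`; compound 2 gives 54.9%
- compound 3 `COc1ccccc1N1CCN(C(=O)c2nc3ccccc3s2)CC1`; compound 3 gives 53.4%

Compound 3 has the lowest of the three numbers, yet its gaps to compound 2 and to compound 1 both lie within the scatter, so nothing separates the three. Compound 4 `CN1CCN(C(=O)c2nc3ccccc3s2)CC1` is not yet measured; it differs from compound 3 in one place: methyl in place of 2-methoxyphenyl on an amine nitrogen in a ring. Among the measured compounds shown here, one measured step touches the same position, a number 8.6 percentage points lower from compound 1 to compound 3 (within the scatter), where one ring group gave way to another without a shift beyond the scatter. Compound 2 differs from compound 1 in two places, so its value shows only that it also sits close to the others. For the measured compounds named here, with all three numbers close and the one comparable step flat, no step beyond the scatter is expected for compound 4, an estimated a number 3.4 percentage points lower from compound 3 to compound 4 (within the scatter). Compound 4 is expected at 50%, between 30% and 68%.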

Compound 4, a percentage reported as inhibition, at one concentration (the size of the read-out at that concentration, not a potency): 52.1%
For compound 4 the middle estimate is 2.1 percentage points below the measured one, and the stated range covers the measured number.
By their numbers in this assay, from the lowest: compounds 4, 3, 2 and 1 (each within the scatter of the next).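

Even a change as large as losing a whole aromatic ring does not move the number beyond the scatter in this assay: methyl replacing 2-methoxyphenyl on the amine nitrogen gives a number 1.3 percentage points lower from compound 3 to compound 4 (within the scatter). Methyl replacing pyridin-4-yl gives a number 9.9 percentage points lower from compound 1 to compound 4 (within the scatter), so among these compounds an aromatic ring on this nitrogen is not required for the read-out at this one concentration. Nothing available explains this result. As far as these compounds go, what a carboxylic acid or a longer chain on this nitrogen would do remains open.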